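The source may hold more compounds than are shown below. What is called first, only, known or untested is meant among the compounds shown, and "the series" means these compounds.

Series values in a functional assay on HL-60 cells (Homo sapiens) for cytotoxicity, read by MTT assay, with a stated time of 3 days; on this read-out lower numbers stand for stronger inhibition and higher numbers for weaker inhibition

compound 1 `N#Cc1c(-c2ccccc2)nc(SCc2nc3ccccc3[nH]2)nc1N1CCNCC1` gives 4 nM
compound 2 `CN1CCN(c2nc(SCc3nc4ccccc4[nH]3)nc(-c3ccccc3)c2C#N)CC1` gives 2.8 nM
compound 3 `Cc1ccc(S(=O)(=O)N2CCN(c3nc(SCc4nc5ccccc5[nH]4)nc(-c4ccccc4)c3C#N)CC2)cc1` gives 4.23 nM

In this assay compound 3 sits level with the other two within the scatter. Its steps are a 1.1-fold higher number from compound 1 to compound 3 (0.02 log units; within the scatter) and a 1.5-fold higher number from compound 2 to compound 3 (0.18 log units; within the scatter), so none of the three compounds stands apart.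

The next compound is compound 4 `N#Cc1c(-c2ccccc2)nc(SCc2nc3ccccc3[nH]2)nc1N1CCN(S(=O)(=O)c2ccccc2[N+](=O)[O-])CC1`, which carries 2-nitrophenyl in place of 4-methylphenyl on a sulfonyl sulfur. For the measured compounds named here, no measured pair varies the group on that sulfur, so there is no direct precedent for this change. The nearest evidence comes from changes one bond further in, on the amine nitrogen in a ring. Those are the two steps above and a 1.4-fold lower number from compound 1 to compound 2 (0.15 log units; within the scatter). Hydrogen, methyl and (4-methylphenyl)sulfonyl at that nitrogen all gave numbers within the scatter, with no compound among these three going against that. This is thin support from a small set, and the range is therefore kept wide.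

The expectation is a 1.1-fold lower number from compound 3 to compound 4 (0.02 log units; within the scatter), which means no expected step beyond the scatter. For compound 4 the estimated value in this assay is 4 nM, with an expected range from 1.5 nM to 12 nM.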

Compound 4, half-maximal inhibitory concentration: 2.77 nM
Compound 4: middle estimate off by 1.4-fold (0.16 log units), on the high side; measured number inside the range.
By their numbers in this assay, from the lowest: compounds 4, 2, 1 and 3 (each within the scatter of the next).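

In this assay, for the compounds shown here, the first change of the group on the sulfonyl sulfur, 2-nitrophenyl in place of 4-methylphenyl, stays within the scatter (a 1.5-fold lower number from compound 3 to compound 4 (0.18 log units; within the scatter)), so this position tolerates a swap of one aryl group for another that adds a nitro group and its 2 hydrogen-bond acceptors. Read at the amine nitrogen in a ring, (2-nitrophenyl)sulfonyl also stays within the scatter of methyl (a 1.0-fold lower number from compound 2 to compound 4 (0.00 log units; within the scatter)) and of hydrogen (a 1.4-fold lower number from compound 1 to compound 4 (0.16 log units; within the scatter)), which makes four groups on that nitrogen with no separation among them and no compound of the four going against this. No measurement shown here offers an explanation for this flat response at the sulfonyl sulfur.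

Open, from the compounds shown here alone, is whether the flat response survives on the sulfonyl sulfur when the aryl ring gives way to a non-aromatic group such as a butyl chain, or when the ring carries a carboxylic acid or an amine. Also open, going by these compounds, is whether a carbonyl-linked group such as acetyl on the amine nitrogen in a ring, in place of the sulfonyl link, would stay within the scatter of these four compounds.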